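Ethoxy in place of propylsulfanyl on the shared core

The source may hold more compounds than are shown below. What is called first, only, known or untested is meant among the compounds shown, and "the series" means these compounds.

Three compounds of the series carry a number in a functional assay on the whole organism (strain NMRI) with Mus musculus as the target, with a stated time of 60 min, at a dose of 5 mg/kg by the intraperitoneal route; on this read-out lower numbers stand for a weaker effect and higher numbers for a stronger effect at the one dose given. Compound 1 `CCSc1nnc(Cc2ccccc2Oc2ccccc2)[nH]1` gives 132%, compound 2 `CCCSc1nnc(Cc2ccccc2Oc2ccccc2)[nH]1` gives 128% and compound 3 `Clc1ccc(Cc2nnc(SCc3ccccc3)[nH]2)c(Oc2ccccc2Cl)c1` gives 113%. Compound 2 thus holds the second place among the three numbers: its gap to compound 1 lies within the scatter, its gap to compound 3 lies beyond it. Among the compounds with values here, the only measured step that alters one place is a number 4 percentage points lower from compound 1 to compound 2 (within the scatter), a change within the scatter.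

Compound 4 `CCOc1nnc(Cc2ccccc2Oc2ccccc2)[nH]1` is not yet measured. It differs from compound 2 as follows: ethoxy in place of propylsulfanyl on an aromatic carbon. Within the data shown here, the step from compound 1 to compound 2 bears on it only in part, since it too alters the group in that same place and stayed within the scatter; no measured step exchanges the sulfur for an oxygen there. The expected step is therefore a number 6 percentage points lower from compound 2 to compound 4 (within the scatter), no larger than the scatter and of uncertain direction. Compound 4 is estimated at 122%, within a range from 102% to 142%.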

Compound 4, a percentage reported as activity, at one dose (the size of the read-out at that dose, not a potency): 123%
For compound 4 the middle estimate is 1 percentage points below the measured one; the measured number falls inside the stated range.
By their numbers in this assay, from the lowest: compounds 3, 4, 2 and 1 (each within the scatter of the next, the first and the last beyond it).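

In this assay, ethoxy in place of propylsulfanyl gives a number 5 percentage points lower from compound 2 to compound 4 (within the scatter) and ethoxy in place of ethylsulfanyl gives a number 9 percentage points lower from compound 1 to compound 4 (within the scatter) at this aromatic carbon between two ring nitrogen atoms. The earlier step altered only the chain on the sulfur, whereas these steps exchange the sulfur itself for an oxygen, and neither leaves the scatter at this dose. Nothing available explains these numbers.

Open is whether an amine or a carboxylic acid on this aromatic carbon, or a longer chain on the sulfur or oxygen, would keep the number within the scatter of these compounds. Within the data shown here, no step at this place yet lies beyond the scatter, so how far the read-out can move through this position remains unknown.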